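Swapping Fluoro for Dimethylamino on a Shared Core

The source may report more compounds than this note shows. Statements on the series, on what has been measured and on what is new or still open speak of the compounds shown alone.

Two measured compounds share one core and differ only in a single group on a phenyl ring. Compound 1 `O=C1/C(=C\c2ccc(O)cc2)c2ccccc2N1c1c(Cl)cccc1Cl` carries a hydroxy group; in a functional assay on MCF7 cells (Homo sapiens) for cytotoxicity, read by MTT assay, with a stated time of 72 h (a lower number here means that less compound is needed, a higher number that more compound is needed for the effect), compound 1 gives 20 ug/mL. Among the measured compounds shown here, compound 2 `O=C1/C(=C\c2ccc(F)cc2)c2ccccc2N1c1c(Cl)cccc1Cl` carries a fluoro group in that place, and in this assay compound 2 gives 9 ug/mL, the lowest of the two numbers so far. That change brought a 2.2-fold lower number from compound 1 to compound 2 (0.35 log units; beyond the scatter), a modest shift.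

Compound 3 `CN(C)c1ccc(/C=C2\C(=O)N(c3c(Cl)cccc3Cl)c3ccccc32)cc1` is not yet measured. It differs from compound 2 by dimethylamino in place of fluoro on an aromatic carbon. For the measured compounds named here, no measured step exchanges fluoro for dimethylamino, so the one known step, a 2.2-fold lower number from compound 1 to compound 2 (0.35 log units; beyond the scatter), bears on it only loosely: it shows that changing the group in this place can move the number by a modest amount. For compound 3 a step of a 1.1-fold lower number from compound 2 to compound 3 (0.05 log units; within the scatter) in this assay is expected, meaning little change beyond the scatter. Compound 3 is estimated at 8 ug/mL, with a range from 3 ug/mL to 20 ug/mL.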

Compound 3, concentration for half-maximal effect: > 100 ug/mL
Compound 3: no number, only a limit; the forecaster's own chance of this, stated with the estimate: 5%; middle value at least 12-fold (1.09 log units) away from the limit.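

In this assay compound 3 has a limit rather than a number: the limit of > 100 ug/mL in this assay, at which 1 of the 3 values shown sits. Exchanging fluoro for dimethylamino gives an at least 11-fold higher number from compound 2 to compound 3 (1.04 log units; beyond the scatter), and exchanging hydroxy for dimethylamino gives an at least 5.0-fold higher number from compound 1 to compound 3 (0.69 log units; beyond the scatter). The hydroxy and fluoro pair showed only a modest shift, whereas these steps show that a change at this place on the phenyl ring can move the number much further, towards more compound being needed.

As far as these compounds go, it remains open whether this jump belongs to the nitrogen or to the two methyl groups of dimethylamino, and a plain amine in the same place would help separate the two. A methoxy group there would also show whether a different oxygen-bearing group stays close to hydroxy or moves towards dimethylamino.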